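The compounds below may be only part of what the source reports. "The series", "measured", "known", "first", "only" and "open" are said of these compounds alone.

Measured compounds:
Compound 1 `C[C@H](Nc1ncnc(N)c1C#N)c1nc2ccc(F)cc2c(-c2ccccn2)c1-c1ccccn1` — in an ADME assay on the whole organism (Rattus norvegicus, strain Sprague-Dawley) for pharmacokinetics, read by LC-MS, at a dose of 0.5 mg/kg by the intravenous route (a lower number here means slower removal, a higher number faster removal of the compound), compound 1 gives "not determined" (no result reported).
Compound 2 `C[C@H](Nc1ncnc(N)c1C#N)c1nc2ccc(F)cc2c(C(N)=O)c1-c1ccccc1` — in this assay compound 2 gives 10 mL/min/kg.

Among the measured compounds shown here, compound 2 is the only compound with a number, so it stands alone on that scale; compound 1 carries no value to set beside it. Compound 3 `CNC(=O)c1c(-c2ccccc2)c([C@H](C)Nc2ncnc(N)c2C#N)nc2ccc(F)cc12` differs from compound 2 by methyl in place of hydrogen on an amide-type nitrogen. For the measured compounds named here, no step between measured compounds is available to guide this change. The clearance of compound 3 is therefore expected to stay within the scatter of compound 2, with a 1.2-fold higher number from compound 2 to compound 3 (0.08 log units; within the scatter). Compound 3 is estimated at 12 mL/min/kg, between 6 mL/min/kg and 24 mL/min/kg.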

Compound 3, clearance: 8.33 mL/min/kg
Beside the measured number, compound 3's estimate is 1.4-fold (0.16 log units) above it; the range from low to high includes it.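

Methyl in place of hydrogen on the amide-type nitrogen gives a 1.2-fold lower number from compound 2 to compound 3 (0.08 log units; within the scatter) in this assay, the only reading of any change at this position. By this read-out, carbamoyl and methylcarbamoyl cannot be told apart, so this nitrogen takes the methyl without a shift beyond the scatter. Nothing in the available data explains this result. As far as these compounds go, whether an ethyl group or a longer chain on this nitrogen would move clearance beyond the scatter remains open. So does the outcome of replacing the carbamoyl with a carboxylic acid.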